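Naphthalen-1-yl for 4-chlorophenyl on a sulfur

This account rests on a few compounds, and the source may have more. Where it says the series, first, only, none or still open, it means among the compounds named here.

Compound 1 `Nc1ccccc1NC(=O)/C=C/c1ccc(CSc2ccc(Cl)cc2)cc1` is the starting point for this step. In a functional assay on A-375 cells (Homo sapiens) for inhibition, read by CCK-8 assay, with a stated time of 72 h, tested at 8 uM (on this read-out lower numbers stand for less inhibition of growth and higher numbers for more inhibition of growth at the one concentration tested), compound 1 gives 48.2% and stands second highest of the three measured compounds. Compound 2 `Cc1ccc(SCc2ccc(C(=O)Nc3ccccc3N)cc2)cc1` gives 67% and lies above it beyond the scatter, while compound 3 `Nc1ccccc1NC(=O)c1ccc(CSc2ccc(Br)cc2)cc1` gives 6.17% and lies below it beyond the scatter.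

Compound 4 `Nc1ccccc1NC(=O)/C=C/c1ccc(CSc2cccc3ccccc23)cc1` carries naphthalen-1-yl in place of 4-chlorophenyl on a sulfur, counted as naphthalen-1-yl in place of 4-chlorophenyl on a sulfur in its difference from compound 1.

Within the data shown here, one measured step bears on this change. Bromo in place of methyl on an aromatic carbon gave a number 60.8 percentage points lower from compound 2 to compound 3 (beyond the scatter) and this step is large, so a modest swap on an aromatic group can matter in this series. However, compound 2 and compound 3 share a core that differs from the core of compound 1, and no measured compound carries naphthalen-1-yl. The data fix neither a direction nor a size for this replacement.

In this assay the central expectation is therefore no shift beyond the scatter, with wide uncertainty. The estimated step is a number 3.2 percentage points lower from compound 1 to compound 4 (within the scatter) as the working figure. For compound 4 the estimated value is 45% with an expected range from 18% to 72% at this stage.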

Compound 4, percent growth inhibition at one concentration: 36%
Estimate against measurement, compound 4: 9 percentage points above; low and high end bracket the measured number.
By their numbers in this assay, from the lowest: compound 3; then compound 4; then compound 1; then compound 2.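

At the sulfur whose other neighbour is a saturated chain carbon, the core of compound 1 now has its first measured replacement: in this assay, naphthalen-1-yl for 4-chlorophenyl gives a number 12.2 percentage points lower from compound 1 to compound 4 (beyond the scatter). The earlier large step concerned a swap on an aromatic carbon in a different core, whereas this step shows that exchanging the whole aromatic group on the sulfur also moves the read-out beyond the scatter on this core. Growth inhibition is reduced but not abolished, since compound 4 still gives 36% at the one concentration tested, and nothing on hand accounts for the drop.

The single step changes two things at once, the number of aromatic rings and the loss of the chloro group, so the compounds shown cannot separate their contributions. Also open, going by these compounds, is how naphthalen-2-yl, an unsubstituted phenyl or a phenyl carrying an amine or a carboxylic acid on the same sulfur would compare on the core of compound 1, and whether the bromo and methyl difference seen on the other core carries over to it.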